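Working notes: extending the side chain to hexyloxy

A few compounds are considered here, and "the series" means these few. Any claim that something is new, unique, unknown or untested is made for them only; others in the source may bear on it.

Measured in a functional assay on brain (Rattus norvegicus, strain Wistar) for inhibition; a higher number here means a weaker inhibitor, a lower number a stronger inhibitor:
- compound 1 `CCCCOc1ccc(-c2c(C)[nH]c(=O)n2C)cc1`: 5100 nM
- compound 2 `CCCc1ccc(-c2c(C)[nH]c(=O)n2C)cc1`: 21500 nM
- compound 3 `CCCCCc1ccc(-c2c(C)[nH]c(=O)n2C)cc1`: 5900 nM

Compound 3 sits level with one measured neighbour and apart from the other: a 1.2-fold higher number from compound 1 to compound 3 (0.06 log units; within the scatter), and a 3.6-fold lower number from compound 2 to compound 3 (0.56 log units; beyond the scatter). Compound 4 `CCCCCCOc1ccc(-c2c(C)[nH]c(=O)n2C)cc1` is the next structure to compare, with the change (hexyloxy in place of pentyl on an aromatic carbon), hexyloxy in place of pentyl on an aromatic carbon. The shorter propyl chain alone stands off, a 4.2-fold higher number from compound 1 to compound 2 (0.62 log units; beyond the scatter), so a longer chain is expected to hold the number or lower it modestly. Within the data shown here, only three compounds support this reading, and none goes against it. The expected move is small: a 2.1-fold lower number from compound 3 to compound 4 (0.32 log units; beyond the scatter). Compound 4 is estimated at 2800 nM, with an expected range of 900 nM to 7500 nM.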

Compound 4, half-maximal inhibitory concentration: 7300 nM
Compound 4: middle estimate off by 2.6-fold (0.42 log units), on the low side, within the range that was stated.
By their numbers in this assay, from the lowest: compounds 1, 3 and 4 (each within the scatter of the next); then compound 2.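

In this assay, hexyloxy and pentyl read level at this position: a 1.2-fold higher number from compound 3 to compound 4 (0.09 log units; within the scatter). Hexyloxy stays clearly apart from propyl, a 2.9-fold lower number from compound 2 to compound 4 (0.47 log units; beyond the scatter), so propyl remains the only chain here that stands off. Ethyl added to the butoxy chain leaves the number within the scatter, a 1.4-fold higher number from compound 1 to compound 4 (0.16 log units; within the scatter), so adding ethyl does not give the same result on both chains: the same change on two cores in this assay, a 3.6-fold lower number (0.56 log units; beyond the scatter) from compound 2 to compound 3 and a 1.4-fold higher number (0.16 log units; within the scatter) from compound 1 to compound 4, 5.2-fold (0.72 log units) apart, beyond the scatter of two such steps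

Still open, on these data alone, is whether the level reading holds for a chain longer than hexyloxy. A chain ending in an amine or a carboxylic acid is also untested among these compounds.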